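The source may hold more compounds than are shown below. What is called first, only, known or untested is meant among the compounds shown, and "the series" means these compounds.

Measured so far:
- compound 1, `CCc1ccc(OC[C@@H]2CCN2)cn1`: 19 nM
- compound 2, `Clc1cncc(OC[C@@H]2CCN2)c1`: 0.042 nM

In an assay on brain for binding affinity to Neuronal acetylcholine receptor; alpha4/beta2 (Rattus norvegicus), read by radioligand binding (a lower number here means a stronger inhibitor, a higher number a weaker inhibitor), compound 2 gives 0.042 nM, the lower of the two numbers; compound 1 gives 19 nM, and the gap between the two lies well beyond the scatter. No single-point step between measured compounds is available, so the pair can only be read as two values with a wide spread and no assignable cause.

Compound 3, `NCc1cncc(OC[C@@H]2CCN2)c1`, has not yet been measured. It differs from compound 2 in one place: aminomethyl in place of chloro on an aromatic carbon.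

Within the data shown here, with no measured step of this kind to lean on, the expectation rests on compound 2 alone, whose 0.042 nM leaves a great deal of room for a weaker number before compound 1 is reached. The change is expected to move this assay in the direction of a higher number, by a step of a 48-fold higher number from compound 2 to compound 3 (1.68 log units; beyond the scatter), clearly beyond the scatter. Compound 3 is therefore estimated at 2 nM, with a range from 0.2 nM to 20 nM.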

Compound 3, inhibition constant: 4.4 nM
Compound 3: the middle estimate sits 2.2-fold (0.34 log units) below what was measured; measured number inside the range.
By their numbers in this assay, from the lowest: compound 2; then compound 3; then compound 1.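

In this assay, a 100-fold higher number from compound 2 to compound 3 (2.02 log units; beyond the scatter) gives the series its first step at a single place, and it shows that this position, two atoms from the ring nitrogen and on the shared core, is far from indifferent to its substituent. Aminomethyl in place of chloro is a large loss, although compound 3 still gives 4.4 nM in the same assay, so this position tolerates a hydrogen-bond donor and acceptor with a measurable number rather than a complete loss of binding. Nothing in hand explains the size of this step.

The compounds shown leave open whether the step reflects the loss of chloro, the arrival of the amine or the added chain length, since all three change together between compound 2 and compound 3. A methyl, a hydroxymethyl or a bromo at this position would help separate these readings, and a longer chain ending in an amine would show whether moving the amine further from the ring changes the number in either direction.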